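A few compounds are considered here, and "the series" means these few. Any claim that something is new, unique, unknown or untested is made for them only; others in the source may bear on it.

Compound 1, with the structure `CC1(C)CC(NC(=S)Nc2cccc(C#N)c2)c2cc(NS(C)(=O)=O)ccc2O1`, compound 2, with the structure `CC1(C)CC(NC(=S)Nc2ccc(C#N)cc2)c2cc(NS(C)(=O)=O)ccc2O1`, and compound 3, with the structure `CCS(=O)(=O)Nc1ccc2c(c1)C(NC(=O)Nc1cccc(C#N)c1)CC(C)(C)O2`, were all examined in a functional assay on thoracic aorta (Rattus norvegicus) for inhibition; on this read-out lower numbers stand for an effect already at smaller amounts and higher numbers for an effect only at larger amounts of compound. In that read-out compound 1 gives 9800 nM, compound 2 gives 11600 nM, and compound 3 gives 9500 nM; the three numbers lie within the usual scatter of one another, so none of them can be set apart from the rest.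

Compound 1 and compound 2 are the same molecule apart from 4-cyanophenyl in place of 3-cyanophenyl on an amide-type nitrogen. The step of a 1.2-fold higher number from compound 1 to compound 2 (0.07 log units; within the scatter) is therefore within the scatter and does not show a real change. Compound 3 and compound 1 differ in more than one place, and the difference between the two cores is not broken down here.

Compound 4, with the structure `CCS(=O)(=O)Nc1ccc2c(c1)C(NC(=O)Nc1ccc(C#N)cc1)CC(C)(C)O2`, has not yet been measured. It stands to compound 3 as compound 2 stands to compound 1: the counted difference is 4-cyanophenyl in place of 3-cyanophenyl on an amide-type nitrogen. The two places are not the same word for word, though. The amide-type nitrogen in compound 3 has a carbonyl carbon as its other neighbour, while in compound 1 it has a thiocarbonyl carbon; the change is of the same kind rather than the same.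

Resting on the flat step a 1.2-fold higher number from compound 1 to compound 2 (0.07 log units; within the scatter), the expected step of a 1.2-fold higher number from compound 3 to compound 4 (0.06 log units; within the scatter) is also small. Compound 4 is accordingly estimated at 11000 nM in this assay, with the likely range running from 6000 nM to 20000 nM.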

Compound 4, half-maximal effective concentration: 11800 nM
Beside the measured number, compound 4's estimate is 1.1-fold (0.03 log units) below it, and the stated range covers the measured number.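

In this assay, 4-cyanophenyl in place of 3-cyanophenyl on an amide-type nitrogen whose other neighbour is a carbonyl carbon gives a 1.2-fold higher number from compound 3 to compound 4 (0.09 log units; within the scatter), so this change shows no real effect on this core either. Set beside the same change on the core of compound 1, the new step does not differ from the earlier one: the same change on two cores in this assay, a 1.2-fold higher number (0.07 log units; within the scatter) from compound 1 to compound 2 and a 1.2-fold higher number (0.09 log units; within the scatter) from compound 3 to compound 4, 1.0-fold (0.02 log units) apart, within the scatter of two such steps. This shows that the flat result holds on both cores, where the amide-type nitrogen has a thiocarbonyl carbon in one pair and a carbonyl carbon in the other, but neither step lies beyond the scatter, so it does not show that a change with a real effect would carry over in the same way, and two pairs set no rule for the whole series.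

The compounds shown leave open whether a different group in place of the nitrile on the phenyl ring, such as a nitro group, a chlorine or a trifluoromethyl group, would move the number beyond the scatter. They also leave open whether a longer chain such as propyl in place of the methyl or ethyl on the sulfonyl group would do so.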